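Iodo for chloro on the amide aryl group

The source may report more compounds than this note shows. Statements on the series, on what has been measured and on what is new or still open speak of the compounds shown alone.

Measured compounds:
compound 1 `Cn1c(Cc2nn(C)c(=O)c3ccccc23)nnc1SCCCCCCCC(=O)Nc1ccc(Br)cc1Br` — 1500 nM
compound 2 `Cn1c(Cc2nn(C)c(=O)c3ccccc23)nnc1SCCCCCCCC(=O)Nc1ccc(Cl)cc1` — 800 nM

In an assay on isolated protein (Mus musculus) for inhibition of IL15-IL15 receptor (Homo sapiens), read by resazurin assay, with stated times of 30 min and 2.5 days (on this read-out lower numbers stand for stronger inhibition and higher numbers for weaker inhibition), compound 2 holds the lower of the two numbers, yet the step of a 1.9-fold lower number from compound 1 to compound 2 (0.27 log units; within the scatter) sits within the scatter. Compound 3 `Cn1c(Cc2nn(C)c(=O)c3ccccc23)nnc1SCCCCCCCC(=O)Nc1ccc(I)cc1` differs from compound 2 by iodo in place of chloro on an aromatic carbon. Among the measured compounds shown here, the only measured step bearing on this, a 1.9-fold lower number from compound 1 to compound 2 (0.27 log units; within the scatter), also exchanged halogens on this ring and stayed within the scatter, so no step beyond the scatter is expected for compound 3: a 1.1-fold lower number from compound 2 to compound 3 (0.06 log units; within the scatter). Compound 3 is estimated at 700 nM, with a range from 300 nM to 1800 nM.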

Compound 3, half-maximal inhibitory concentration: 1300 nM
Beside the measured number, compound 3's estimate is 1.9-fold (0.27 log units) below it; the range from low to high includes it.
By their numbers in this assay, from the lowest: compounds 2, 3 and 1 (each within the scatter of the next).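

In this assay, the step from chloro to iodo on this aromatic carbon stays within the scatter (a 1.6-fold higher number from compound 2 to compound 3 (0.21 log units; within the scatter)), so these two halogens are not told apart here. The 4-iodophenyl amide is likewise not separated from the 2,4-dibromophenyl amide (a 1.2-fold lower number from compound 1 to compound 3 (0.06 log units; within the scatter)). No accompanying measurement offers an explanation for these results. The compounds shown leave open whether a group other than a halogen on this ring, such as an amine, a methoxy group or a carboxylic acid, would give a step beyond the scatter. They also leave open what a shorter chain would do.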